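The source may hold more compounds than are shown below. What is called first, only, known or untested is meant among the compounds shown, and "the series" means these compounds.

Working notes on the series in an ADME assay on cells for inhibition of cytochrome P450 11B1, mitochondrial (Homo sapiens), read by HPLC, with a stated time of 60 min; a lower number here means a stronger inhibitor, a higher number a weaker inhibitor. Compound 1 `Fc1ccc2nc(-n3ccnn3)n(C3CC3)c2c1` gives 9070 nM in this assay. Compound 2 `Fc1ccc2nc(-c3ccnnc3)n(C3CC3)c2c1` returns only a limit in this assay, > 10000 nM. Compound 2 thus sits at the limit of > 10000 nM in this assay, at which 1 of the 3 values shown sits. Among the compounds with values here, the one single-point step available, an at least 1.1-fold higher number from compound 1 to compound 2 (0.04 log units; that floor lies within the scatter), is therefore an exchange of one heteroaryl for another with no resolved change in number. Compound 3 `Fc1cc2nc(-c3cncnc3)n(C3CC3)c2cc1F`, which carries a second fluorine on the shared core and a different six-membered aromatic ring with two nitrogens, gives 2270 nM in this assay; this is the lowest of the two numbers that are numbers, and its nearest neighbour among them, compound 1, sits at a higher number, a gap beyond the scatter.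

Compound 4 `N#Cc1ncncc1-c1nc2cc(F)c(F)cc2n1C1CC1` is compound 3 with a small change: cyano in place of hydrogen on an aromatic carbon, placed on an aromatic carbon of a six-membered aromatic ring with two nitrogens, next to the ring nitrogen, ortho to a large group and opposite the ring nitrogen. Within the data shown here, no measured step in this set adds a cyano group or alters a substituent on that ring; the only measured step, the heteroaryl swap from compound 1 to compound 2, does not bear on this change. The expectation for compound 4 is therefore a step of uncertain direction, most likely within the scatter, expressed as a 1.5-fold lower number from compound 3 to compound 4 (0.18 log units; within the scatter). Compound 4 is accordingly estimated at 1500 nM in this assay, with a range from 400 nM to 6000 nM.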

Compound 4, half-maximal inhibitory concentration: 4990 nM
Compound 4: the middle estimate sits 3.3-fold (0.52 log units) below what was measured, within the range that was stated.
By their numbers in this assay, from the lowest: compound 3; then compounds 4 and 1 (each within the scatter of the next). At a limit, above all of these: compound 2.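

In this assay, within the data shown here, the cyano group gives the first measured step on the six-membered aromatic ring with 2 nitrogen, at the aromatic carbon next to the ring nitrogen, ortho to a large group and opposite the ring nitrogen: a 2.2-fold higher number from compound 3 to compound 4 (0.34 log units; beyond the scatter). The earlier compounds shown here varied the heteroaryl and the fluorine substitution of the shared core but gave no reading on a substituent at this ring carbon; this single step shows that cyano in place of hydrogen here moves the number towards weaker inhibition, not towards stronger inhibition, by a modest amount. The compounds shown provide no measurement that accounts for this step.

On these data alone, this is one substituent at one ring carbon on one core, so it remains open whether a methyl group, a methoxy group or an amine at the same carbon would give a lower or a higher number than hydrogen does in compound 3. As far as these compounds go, it is also open whether the same cyano change would give a step of similar direction and size on the core of compound 1, which carries one fluorine, or on another heteroaryl ring.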